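Swapping the carbonyl substituent on the shared core

The source may hold more compounds than are shown below. What is called first, only, known or untested is meant among the compounds shown, and "the series" means these compounds.

Within the data shown here, in an ADME assay on L02 cells (Homo sapiens) for cytotoxicity, read by MTT assay, with a stated time of 48 h (on this read-out higher numbers stand for weaker inhibition and lower numbers for stronger inhibition), compound 1 `CCn1c(C(=O)NCCN(C)C)ccc1C(CC)(CC)c1ccc(OCC(O)C(C)(C)C)c(C)c1` gives 2600 nM and compound 2 `C=CCN(C)C(=O)c1ccc(C(CC)(CC)c2ccc(OCC(O)C(C)(C)C)c(C)c2)n1CC` gives 6300 nM, the higher of the two numbers so far. Compound 3 `C#CC(C)OC(=O)c1ccc(C(CC)(CC)c2ccc(OCC(O)C(C)(C)C)c(C)c2)n1CC` follows from compound 2 by one change on the carbonyl carbon: (1-methylprop-2-yn-1-yl)oxy in place of allyl(methyl)amino ((1-methylprop-2-yn-1-yl)oxy in place of allyl(methyl)amino on a carbonyl carbon). Among the measured compounds shown here, only one measured step bears on this, and only loosely. That step, a 2.4-fold higher number from compound 1 to compound 2 (0.38 log units; beyond the scatter), is modest and brought allyl(methyl)amino onto the same carbonyl carbon. For the measured compounds named here, no measured compound carries a group attached there through oxygen, so the data give no firm direction. No step beyond the scatter is expected in this assay, with at most a slight upward lean. The expected change is a 1.2-fold higher number from compound 2 to compound 3 (0.08 log units; within the scatter). For compound 3 the estimated value is 7500 nM, with an expected range of 2800 nM to 20000 nM.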

Compound 3, half-maximal inhibitory concentration: 23700 nM
Beside the measured number, compound 3's estimate is 3.2-fold (0.50 log units) below it; the whole stated range lies below it.
By their numbers in this assay, from the lowest: compound 1; then compound 2; then compound 3.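

Attachment through oxygen on this carbonyl carbon is not a neutral exchange for attachment through nitrogen: in this assay, (1-methylprop-2-yn-1-yl)oxy in place of allyl(methyl)amino gives a 3.8-fold higher number from compound 2 to compound 3 (0.58 log units; beyond the scatter), although both groups have 5 heavy atoms and no ring. Against the (2-(dimethylamino)ethyl)amino group, the same change gives a 9.1-fold higher number from compound 1 to compound 3 (0.96 log units; beyond the scatter), so all three groups at this position separate beyond the scatter, with the oxygen-linked group giving the weakest inhibition of the set. No available evidence accounts for these steps.

The oxygen link and the triple bond enter together, so their contributions remain unseparated. A methyl ester, or an amide carrying the same 1-methylprop-2-yn-1-yl chain on nitrogen, would tell them apart.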